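Series notes: solubility from compound 3 to compound 4

The compounds below may be only part of what the source reports. "The series", "measured", "known", "first", "only" and "open" are said of these compounds alone.

In a physicochemical assay for solubility, in phosphate buffer, at pH 7.4 (a higher number here means a more soluble compound, a lower number a less soluble compound), compound 1 `OCC1CCN(c2nccnc2Oc2ccc(Nc3nc4ccccc4s3)cc2)CC1` gives 6000 nM, compound 2 `OCC1CCN(c2nccnc2OC2CN(c3nc4ccccc4s3)C2)CC1` gives 31000 nM and compound 3 `N#CC1CCN(c2nccnc2OC2CN(c3ccc4ccccc4n3)C2)CC1` gives 66000 nM, so compound 3 stands highest of the three numbers, beyond the scatter from both others. Compound 4 `c1ccc2nc(N3CC(Oc4nccnc4-c4ccc5scnc5c4)C3)ccc2c1` is not yet measured. It differs from compound 3 in one place: 1,3-benzothiazol-5-yl in place of 4-cyanopiperidin-1-yl on an aromatic carbon. Going by the values given here, no step of this kind has been measured, so the size of the change can only be guessed. A sizeable drop in this assay is expected, because compound 1, which also carries a benzothiazole, gives 6000 nM. For compound 4 the estimate in this assay is 4000 nM, with a range of 800 nM to 20000 nM, meaning an expected step of a 17-fold lower number from compound 3 to compound 4 (1.22 log units; beyond the scatter).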

Compound 4, solubility: < 1000 nM
Compound 4: a limit, no number; the forecaster's own chance of this, stated with the estimate: 10%; middle value at least 4.0-fold (0.60 log units) away from the limit.
By their numbers in this assay, from the lowest: compound 1; then compound 2; then compound 3. At a limit, below all of these: compound 4.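

In this assay compound 4 gives < 1000 nM, which is a limit of the assay and not a number: the limit of < 1000 nM in this assay, at which 1 of the 4 values shown sits. With 1,3-benzothiazol-5-yl in place of 4-cyanopiperidin-1-yl on this aromatic carbon, the series has its first single-place step, an at least 66-fold lower number from compound 3 to compound 4 (1.81 log units; beyond the scatter). Going by these compounds alone, the read-out at this position therefore moves by a large margin with this change, which the earlier compounds, differing in more than one place, could not show.

From the compounds shown here alone, the true size of the step remains open. So does how an unsubstituted piperidine, an open-chain amine or a carboxylic acid at this position would read in this assay.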